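This account rests on a few compounds, and the source may have more. Where it says the series, first, only, none or still open, it means among the compounds named here.

Measured compounds in a functional assay on L1210 cells (Mus musculus) for inhibition, read by MTT assay; a lower number here means a stronger inhibitor, a higher number a weaker inhibitor:

Compound 1, `CCOC(=O)c1ccc(NC(=O)N2CC2C#N)cc1`: 9700 nM
Compound 2, `N#CC1CN1C(=O)Nc1cccc2ccccc12`: 7200 nM

Both compounds share a core in which a nitrile-bearing three-membered ring is joined through a urea to an aromatic ring. Compound 1 stands at the top of the two numbers in this assay, but its gap to compound 2 is within the usual scatter, so the two cannot be told apart on these data.

Compound 3, `N#CC1CN1C(=O)Nc1ccc(C(F)(F)F)cc1`, has not yet been measured. It differs from compound 1 by trifluoromethyl in place of ethoxycarbonyl on an aromatic carbon. Going by the values given here, no step between two measured compounds is known here, so the size of this change can only be guessed. The expectation is a step of a 1.4-fold lower number from compound 1 to compound 3 (0.14 log units; within the scatter) from compound 1 to compound 3 in this assay, that is, nothing clearly beyond the scatter, with a slight lean toward a lower number. Compound 3 is therefore estimated at 7000 nM, with a range from 2500 nM to 20000 nM.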

Compound 3, half-maximal inhibitory concentration: 7800 nM
Estimate against measurement, compound 3: 1.1-fold (0.05 log units) below; low and high end bracket the measured number.
By their numbers in this assay, from the lowest: compounds 2, 3 and 1 (each within the scatter of the next).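

In this assay, putting trifluoromethyl in place of ethoxycarbonyl on this aromatic carbon, para to a group of 8 heavy atoms, gives a 1.2-fold lower number from compound 1 to compound 3 (0.09 log units; within the scatter) and so yields no difference that can be read. Going by these compounds alone, this is the first direct look at this position: ethoxycarbonyl carries 5 heavy atoms and 2 hydrogen-bond acceptors, trifluoromethyl 4 heavy atoms and 0 hydrogen-bond acceptors, and this exchange leaves the two compounds indistinguishable in this assay. Nothing available explains why they read alike.

Within the data shown here, only this single exchange has been seen at this position, so it remains open whether an amine or a carboxylic acid there would shift the number beyond the scatter. As far as these compounds go, a longer chain in the same place is equally open.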